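Swapping pentafluorophenyl for 3-fluorophenyl on a shared core

The compounds below may be only part of what the source reports. "The series", "measured", "known", "first", "only" and "open" are said of these compounds alone.

Compound 1 `CN1CC[C@H](c2c(O)cc(O)c3c(=O)cc(/C=C/c4ccc(Cl)cc4)oc23)[C@H](O)C1` gives 88%
Compound 2 `CN1CC[C@H](c2c(O)cc(O)c3c(=O)cc(/C=C/c4c(F)c(F)c(F)c(F)c4F)oc23)[C@H](O)C1` gives 89%

Both numbers come from a functional assay on MIA PaCa-2 cells (Homo sapiens) for inhibition, read by MTT assay, with a stated time of 48 h, tested at 10 uM; on this read-out lower numbers stand for less inhibition of growth and higher numbers for more inhibition of growth at the one concentration tested. In this test, compound 2 gives 89%, which is level with compound 1 within the usual scatter. The next candidate is compound 3 `CN1CC[C@H](c2c(O)cc(O)c3c(=O)cc(/C=C/c4cccc(F)c4)oc23)[C@H](O)C1`, which keeps the shared core and changes one group: 3-fluorophenyl in place of 2,3,4,5,6-pentafluorophenyl on a double-bonded chain carbon bound to a double-bonded chain carbon. It carries 3-fluorophenyl in place of 2,3,4,5,6-pentafluorophenyl on a double-bonded chain carbon bound to a double-bonded chain carbon.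

Within the data shown here, only one measured step bears on this change, as it replaces a group at the same place: a number 1 percentage points higher from compound 1 to compound 2 (within the scatter). That single step is thin evidence, but it gives no reason to expect a change beyond the scatter in this assay. The expected step is small, at most a slight loss: a number 4 percentage points lower from compound 2 to compound 3 (within the scatter). Compound 3 is estimated at 85%, with an expected range of 68% to 96%.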

Compound 3, percent growth inhibition at one concentration: 67%
The estimate for compound 3 lay 18 percentage points above the measured number; the whole stated range lies above it.
By their numbers in this assay, from the lowest: compound 3; then compounds 1 and 2 (each within the scatter of the next).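

The group on a double-bonded chain carbon bound to a double-bonded chain carbon matters in this assay: 3-fluorophenyl gives a number 22 percentage points lower from compound 2 to compound 3 (beyond the scatter) and also a number 21 percentage points lower from compound 1 to compound 3 (beyond the scatter) when set against 4-chlorophenyl. Compound 1 and compound 2 had stood level within the scatter despite carrying quite different halogenated rings, so this position could have seemed to accept any such ring, and compound 3 shows that it does not. Nothing in the data explains the loss seen with compound 3.

From the compounds shown here alone, with three groups, it stays open whether the loss follows the number of halogen atoms, the kind of halogen or where it sits on the ring. A 4-fluorophenyl group, a plain phenyl ring or a phenyl ring bearing an amine could help to separate these possibilities in this assay.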